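The source may hold more compounds than are shown below. What is called first, only, known or untested is meant among the compounds shown, and "the series" means these compounds.

Measured in a physicochemical assay for solubility; on this read-out lower numbers stand for lower solubility and higher numbers for higher solubility:
- Compound 1 `O=S(=O)(Nc1nccs1)c1ccc2c(c1)OCC[C@@H]2c1ccc(C(F)(F)F)cc1-c1ccc(F)cc1`: 39000 nM
- Compound 2 `O=S(=O)(Nc1nccs1)c1ccc2c(c1)OCC[C@@H]2c1ccc(C(F)(F)F)cc1-c1nccs1`: 15000 nM
- Compound 3 `O=C1COCCN1c1cc(C(F)(F)F)ccc1[C@H]1CCOc2cc(S(=O)(=O)Nc3nccs3)ccc21`: 695000 nM

Compound 3 stands highest of the three at 695000 nM. Compound 4 `O=S(=O)(Nc1nccs1)c1ccc2c(c1)OCC[C@@H]2c1ccc(C(F)(F)F)cc1-c1ccc(F)nc1` keeps the shared core and differs from compound 3 in one place: 6-fluoropyridin-3-yl in place of 3-oxomorpholin-4-yl on an aromatic carbon. Two measured steps introduce the departing 3-oxomorpholin-4-yl, and both are large: an 18-fold higher number from compound 1 to compound 3 (1.25 log units; beyond the scatter) and a 46-fold higher number from compound 2 to compound 3 (1.67 log units; beyond the scatter). The swap to compound 4 runs the opposite way, towards a six-membered aromatic ring. Compound 1, with 4-fluorophenyl in that place, shows 39000 nM, so a large drop is expected. Within the data shown here, no measured compound carries 6-fluoropyridin-3-yl, so the size remains uncertain. The expected step is a 20-fold lower number from compound 3 to compound 4 (1.30 log units; beyond the scatter). For compound 4 the estimated value is 35000 nM, with an expected range of 12000 nM to 100000 nM.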

Compound 4, solubility: 21000 nM
For compound 4 the middle estimate is 1.7-fold (0.22 log units) above the measured one, and the stated range covers the measured number.
By their numbers in this assay, from the lowest: compounds 2, 4 and 1 (each within the scatter of the next, the first and the last beyond it); then compound 3.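

In this assay the change gives a 33-fold lower number from compound 3 to compound 4 (1.52 log units; beyond the scatter) and so places a third aromatic group at this position well short of 3-oxomorpholin-4-yl. The other two readings are a 1.4-fold higher number from compound 2 to compound 4 (0.15 log units; within the scatter) and a 1.9-fold lower number from compound 1 to compound 4 (0.27 log units; within the scatter) and both lie within the scatter, so 6-fluoropyridin-3-yl cannot be told apart from either group, although those two differ from each other beyond it. No measurement shown here explains the gap.

Since 3-oxomorpholin-4-yl is the only non-aromatic group shown, it remains open whether the high number belongs to that ring alone. An amine, a carboxylic acid or a simple morpholine at this position could test that.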